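Adding a methoxy group to the fluorophenyl arm

The source may hold more compounds than are shown below. What is called first, only, known or untested is meant among the compounds shown, and "the series" means these compounds.

Three compounds sharing one core were tested in a functional assay on HCT-116 cells (Homo sapiens) for inhibition, read by MTT assay, with a stated time of 72 h; a higher number here means a weaker inhibitor, a lower number a stronger inhibitor. Compound 2 `O=c1oc2cc(-c3cnc4[nH]ccc4c3)ccc2n1Cc1ccc(F)cc1` gives 5990 nM, the lowest of the three numbers. Compound 3 `O=c1oc2cc(-c3c[nH]c4ncccc34)ccc2n1Cc1ccc(F)cc1` gives 11800 nM; the difference a 2.0-fold higher number from compound 2 to compound 3 (0.29 log units; within the scatter) lies within the scatter, so these two cannot be ranked against each other. Compound 1 `COc1cc(-c2ccc3c(c2)oc(=O)n3Cc2ccc(F)cc2)cnc1N` gives 36400 nM; the step of a 6.1-fold lower number from compound 1 to compound 2 (0.78 log units; beyond the scatter) is beyond the scatter, as is a 3.1-fold lower number from compound 1 to compound 3 (0.49 log units; beyond the scatter).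

Compound 4 `COc1cc(Cn2c(=O)oc3cc(-c4cnc5[nH]ccc5c4)ccc32)ccc1F` has not yet been measured. It differs from compound 2 by methoxy in place of hydrogen on an aromatic carbon, so that 4-fluorophenyl becomes 4-fluoro-3-methoxyphenyl. Within the data shown here, all three measured steps exchange the group on the far side of the core; none touches the fluorophenyl arm, so no measured step bears on this change. For compound 4 the expected step is therefore a 1.1-fold lower number from compound 2 to compound 4 (0.04 log units; within the scatter), a change that should stay within the scatter. Compound 4 is estimated at 5500 nM, with a range from 2000 nM to 16000 nM.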

Compound 4, half-maximal inhibitory concentration: 8050 nM
The estimate for compound 4 lay 1.5-fold (0.17 log units) below the measured number, and the stated range covers the measured number.
By their numbers in this assay, from the lowest: compounds 2, 4 and 3 (each within the scatter of the next); then compound 1.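

Among these compounds, the step of a 1.3-fold higher number from compound 2 to compound 4 (0.13 log units; within the scatter) in this assay is the first measured change to the fluorophenyl arm, so 4-fluorophenyl and 4-fluoro-3-methoxyphenyl cannot be ranked against each other. The earlier steps shown here all lay on the far side of the core, whereas this one shows that a methoxy group ortho to the fluoro group leaves the number within the scatter. Nothing measured here offers an explanation for this result.

Going by these compounds, whether another group on this carbon, such as ethoxy, hydroxyl or dimethylamino, would move the number beyond the scatter remains open. On these data alone, it is also open whether this methoxy group would have a similarly small effect with the far-side group of compound 3 or compound 1 in place of that of compound 2.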